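Urea aryl swap on a pyrazole scaffold: predicting compound 3

This account rests on a few compounds, and the source may have more. Where it says the series, first, only, none or still open, it means among the compounds named here.

Measured compounds:
compound 1 `COc1cc(Cl)cc(-c2nn(-c3cccc(NC(=O)Nc4ccc(Cl)c(C(F)(F)F)c4)c3)cc2-c2ccncc2)c1` — 5.2%
compound 2 `COc1cc(Cl)cc(-c2nn(-c3cccc(NC(=O)Nc4ccc(Cl)c(Cl)c4)c3)cc2-c2ccncc2)c1` — 11.4%

In a functional assay on A549 cells (Homo sapiens) for inhibition, read by sulforhodamine B assay, with a stated time of 48 h, tested at 10 uM (on this read-out higher numbers stand for a weaker effect at the one concentration tested and lower numbers for a stronger effect), compound 1 gives 5.2%, and compound 2 gives 11.4%. Compound 2 thus holds the higher of the two numbers, yet the step of a number 6.2 percentage points higher from compound 1 to compound 2 (within the scatter) lies within the scatter, so the two compounds cannot be ranked on this read-out.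

Compound 3 `COc1cc(Cl)cc(-c2nn(-c3cccc(NC(=O)Nc4cccc(C(F)(F)F)c4)c3)cc2-c2ccncc2)c1` has not been measured. It differs from compound 2 by 3-(trifluoromethyl)phenyl in place of 3,4-dichlorophenyl on an amide-type nitrogen. Among the compounds with values here, only one measured step bears on this: the exchange of a trifluoromethyl for a chloro on the same aromatic ring, a number 6.2 percentage points higher from compound 1 to compound 2 (within the scatter), which changed nothing beyond the scatter. The step to compound 3 goes further, since one chloro is lost and the other is replaced by trifluoromethyl, but the available data give no sign that these groups drive the read-out.

Compound 3 is therefore expected to stay near compound 2, with a step of a number 3.6 percentage points higher from compound 2 to compound 3 (within the scatter) and an estimated value of 15%, ranging from 3% to 35%.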

Compound 3, a percentage reported as activity, at one concentration (the size of the read-out at that concentration, not a potency): 8.08%
Estimate against measurement, compound 3: 6.9 percentage points above; the range from low to high includes it.
By their numbers in this assay, from the lowest: compounds 1, 3 and 2 (each within the scatter of the next).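

In this assay, 3-(trifluoromethyl)phenyl in place of 3,4-dichlorophenyl on the amide-type nitrogen gives a number 3.3 percentage points lower from compound 2 to compound 3 (within the scatter), and hydrogen in place of chloro on an aromatic carbon gives a number 2.9 percentage points higher from compound 1 to compound 3 (within the scatter). The earlier pair only exchanged trifluoromethyl and chloro, with the other chloro kept on the ring; these steps add that the aryl group on this nitrogen can also lose a chloro without any step beyond the scatter, so the three compounds cannot be ranked on this read-out. No measurement at hand accounts for this lack of separation.

Every aryl group shown on this nitrogen carries a chloro or a trifluoromethyl, so it remains open whether the read-out would hold with a plain phenyl, or with a ring bearing an amine or a carboxylic acid. The read-out comes from a single concentration, and these values leave open whether a stronger or weaker effect at another concentration would separate compounds that cannot be told apart here.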